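A few compounds are considered here, and "the series" means these few. Any claim that something is new, unique, unknown or untested is made for them only; others in the source may bear on it.

Working notes on the series. Compound 1 `CC(C)(C)N(NC(=O)c1ccccc1)C(=O)c1ccccc1F` and compound 2 `CC(C)(C)N(NC(=O)c1ccccc1)C(=O)c1ccccc1Br` share one core and differ only in the halogen on an aromatic carbon. In an assay on cells for agonist activity at ecdysone receptor (Bombyx mori), read by a luciferase reporter, with a stated time of 24 h (on this read-out higher numbers stand for an effect only at larger amounts of compound and lower numbers for an effect already at smaller amounts), compound 1 gives 309 nM, and compound 2 gives 170 nM. For the measured compounds named here, compound 2 thus holds one of only two numbers so far, and the other lies within the scatter of it: a 1.8-fold lower number from compound 1 to compound 2 (0.26 log units; within the scatter). The next member, compound 3 `CC(C)(C)N(NC(=O)c1ccccc1)C(=O)c1ccccc1I`, carries the change (iodo in place of bromo on an aromatic carbon). Going by the values given here, the only measured step that bears on this change is a 1.8-fold lower number from compound 1 to compound 2 (0.26 log units; within the scatter), a halogen exchange at the same place that did not leave the scatter. For the present step a similar size at most is expected, leaning if anything toward a lower number, so the expected step from compound 2 to compound 3 in this assay is a 1.3-fold lower number from compound 2 to compound 3 (0.12 log units; within the scatter). For compound 3 the estimate in this assay is 130 nM, with a range from 50 nM to 350 nM.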

Compound 3, half-maximal effective concentration: 105 nM
The estimate for compound 3 lay 1.2-fold (0.09 log units) above the measured number, and the stated range covers the measured number.
By their numbers in this assay, from the lowest: compounds 3, 2 and 1 (each within the scatter of the next, the first and the last beyond it).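

In (this assay) the exchange of bromo for iodo on this aromatic carbon, ortho to a large group, stays inside the scatter (a 1.6-fold lower number from compound 2 to compound 3 (0.21 log units; within the scatter)), as the earlier halogen exchange at this place did. What is new is that the halogen set at this place now holds a pair that lies beyond the scatter, a modest step (a 2.9-fold lower number from compound 1 to compound 3 (0.47 log units; beyond the scatter)), while compound 2 remains within the scatter of both compound 1 and compound 3. No measurement at hand speaks to what lies behind the differences among these halogens.

The compounds shown leave open how a group other than a halogen, such as an amine, a methoxy group or a carboxylic acid, would read at this place. Also open, going by these compounds, is whether the same halogen exchange would give steps of similar size with a further group elsewhere on the shared core.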